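From Methoxy to Trifluoromethyl on an Iodinated Hydrazone

The source may report more compounds than this note shows. Statements on the series, on what has been measured and on what is new or still open speak of the compounds shown alone.

In a functional assay on HepG2 cells (Homo sapiens) for cytotoxicity, with a stated time of 24 h (on this read-out higher numbers stand for weaker inhibition and lower numbers for stronger inhibition), compound 1 `O=C(N/N=C/c1cc(I)cc(I)c1O)c1ccccc1` gives > 50000 nM, which is a limit of the assay rather than a number. Compound 2 `O=C(N/N=C/c1cc(I)cc(I)c1O)c1ccc(F)cc1` gives 12100 nM in this assay. Going by the values given here, those two form the one measured step, an at least 4.1-fold lower number from compound 1 to compound 2 (0.61 log units; beyond the scatter), a move toward stronger inhibition that lies beyond the usual scatter. Compound 3 `COc1ccc(C(=O)N/N=C/c2cc(I)c(O)c(I)c2)cc1` gives > 100000 nM in this assay, again a limit of the assay and not a number, so compound 3 sits at the limit of > 100000 nM in this assay, at which 1 of the 3 values shown sits, and shows no inhibition that can be quantified on the numbers shown.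

Compound 4 `O=C(N/N=C/c1cc(I)c(O)c(I)c1)c1ccc(C(F)(F)F)cc1` differs from compound 3 in one place: trifluoromethyl in place of methoxy on an aromatic carbon, on an aromatic carbon of a six-membered aromatic ring of carbon only, para to a large group. Among the compounds with values here, the only measured step that bears on this is the one from compound 1 to compound 2, where fluoro in place of hydrogen on an aromatic carbon gave an at least modest move to a lower number. Here a methoxy leaves while a trifluoromethyl enters, a different exchange, so the evidence is thin. The expected step is an at least 2.5-fold lower number from compound 3 to compound 4 (0.39 log units; beyond the scatter), modest and toward a lower number. Compound 4 is therefore estimated at 40000 nM, with a range from 12000 nM to 120000 nM, and a real chance that only a limit is reported.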

Compound 4, half-maximal inhibitory concentration: 57400 nM
Compound 4: middle estimate off by 1.4-fold (0.16 log units), on the low side, within the range that was stated.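

Trifluoromethyl in place of methoxy, on an aromatic carbon para to a large group, gives in this assay an at least 1.7-fold lower number from compound 3 to compound 4 (0.24 log units; that floor lies within the scatter), so this change cannot be said to move the number beyond the scatter, though the true step may be larger. On the core of compound 3, compound 4 gives a true number rather than a limit, 57400 nM, which offers a fixed point at this position that later changes there could be compared with. The step stays a floor because compound 3 stands at a limit and not at a number: the limit of > 100000 nM in this assay, at which 1 of the 4 values shown sits.

The compounds shown leave open how the number at this position would respond to an amine, a carboxylic acid or a longer chain, since methoxy and trifluoromethyl are the only two groups seen there on this core. They also leave open whether the lower number seen with trifluoromethyl comes from adding that group or from losing methoxy, a question that the plain hydrogen compound on the same core would help to settle.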